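Bromo to chloro: from compound 2 to compound 3

This account rests on a few compounds, and the source may have more. Where it says the series, first, only, none or still open, it means among the compounds named here.

Measured in a functional assay on MCF7 cells (Homo sapiens); a lower number here means a stronger inhibitor of growth, a higher number a weaker inhibitor of growth:
- compound 1 `O=S(=O)(/C=C/c1ccc(Cl)cc1)Cc1ccc(Nc2ncnc3ccccc23)cc1` gives 52000 nM
- compound 2 `O=S(=O)(/C=C/c1ccc(Br)cc1)Cc1ccc(Nc2ncnc3ccc(Br)cc23)cc1` gives 5000 nM

Of these two, compound 2 has the lower number, and the gap to compound 1 lies beyond the scatter. Compound 3 `O=S(=O)(/C=C/c1ccc(Cl)cc1)Cc1ccc(Nc2ncnc3ccc(Br)cc23)cc1` differs from compound 2 by chloro in place of bromo on an aromatic carbon, with chloro in place of bromo on an aromatic carbon, para to a large group. For the measured compounds named here, no measured pair isolates this change, so no step beyond the scatter is expected in this assay, with the expectation anchored on compound 2 at 5000 nM. The expected change is a 1.3-fold higher number from compound 2 to compound 3 (0.11 log units; within the scatter). The estimate for compound 3 is 6500 nM, with an expected range of 2500 nM to 20000 nM.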

Compound 3, concentration for 50% growth inhibition: 46000 nM
Compound 3: middle estimate off by 7.1-fold (0.85 log units), on the low side; the whole stated range lies below it.
By their numbers in this assay, from the lowest: compound 2; then compounds 3 and 1 (each within the scatter of the next).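

In this assay, the halogen on this ring carries real weight: 4-bromophenyl to 4-chlorophenyl gives a 9.2-fold higher number from compound 2 to compound 3 (0.96 log units; beyond the scatter), so this single-atom exchange is enough to separate the two compounds. With 4-chlorophenyl kept, bromo in place of hydrogen on an aromatic carbon gives a 1.1-fold lower number from compound 1 to compound 3 (0.05 log units; within the scatter), a step within the scatter. No measured evidence bears on why bromo and chloro differ here. On these data alone, whether the bromo on the core counts once 4-bromophenyl is present stays open, as does how a methoxy group or an amine in place of the halogen would read in this assay.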